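The compounds below may be only part of what the source reports. "The series", "measured", "known", "first", "only" and "open" are said of these compounds alone.

Measured so far in a functional assay on NCI-H929 cells (Homo sapiens) for cytotoxicity, read by MTT assay, with a stated time of 72 h (a higher number here means a weaker inhibitor, a lower number a stronger inhibitor), for this series:
Compound 1 (`C=C1C2=C(C(=O)N1OC)[C@H](OC(=O)CSc1nc3ccccc3o1)[C@@](C)(O)[C@H](CCCCC)O2`) 3000 nM
Compound 2 (`C=C1C2=C(C(=O)N1OC)[C@H](OC(=O)CSc1nc3ccccc3s1)[C@@](C)(O)[C@H](CCCCC)O2`) 590 nM

Compound 2 holds the lower number of the two (590 nM). In compound 3 (`C=C1C2=C(C(=O)N1OC)[C@H](OC(=O)CCCCCl)[C@@](C)(O)[C@H](CCCCC)O2`), 3-chloropropyl replaces (1,3-benzothiazol-2-yl)sulfanyl on a saturated chain carbon bound to a carbonyl carbon (3-chloropropyl in place of (1,3-benzothiazol-2-yl)sulfanyl on a saturated chain carbon bound to a carbonyl carbon). For the measured compounds named here, only one measured step bears on this, and only indirectly: 1,3-benzothiazol-2-yl in place of 1,3-benzoxazol-2-yl on a sulfur (a 5.1-fold lower number from compound 1 to compound 2 (0.71 log units; beyond the scatter)), modest but beyond the scatter. Going by the values given here, no measured compound is without a sulfur-bound aromatic group, so the direction is uncertain. A moderately higher number in this assay is expected (a 2.5-fold higher number from compound 2 to compound 3 (0.41 log units; beyond the scatter)). For compound 3 the estimated value is 1500 nM (expected range 350 nM to 6000 nM).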

Compound 3, half-maximal inhibitory concentration: 2500 nM
Estimate against measurement, compound 3: 1.7-fold (0.22 log units) below, and the stated range covers the measured number.
By their numbers in this assay, from the lowest: compound 2; then compounds 3 and 1 (each within the scatter of the next).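

In this assay, the change to 3-chloropropyl gives a 4.2-fold higher number from compound 2 to compound 3 (0.63 log units; beyond the scatter), so the lower number of compound 2 does not survive the loss of (1,3-benzothiazol-2-yl)sulfanyl. The other comparison gives a 1.2-fold lower number from compound 1 to compound 3 (0.08 log units; within the scatter), within the scatter: at this place, a chain with no ring matches (1,3-benzoxazol-2-yl)sulfanyl, so an aromatic group here does not by itself give a lower number. No available evidence accounts for either step.

Still open, on these data alone, is whether the sulfur or the fused ring system carries the benefit in compound 2, which a phenylsulfanyl group would address. Also open, as far as these compounds go, is whether the chlorine matters, or whether an amine or carboxylic acid at the chain end would shift the number.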